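Distal aryl substituent: chloro gives way to diethylamino

This account rests on a few compounds, and the source may have more. Where it says the series, first, only, none or still open, it means among the compounds named here.

Within the data shown here, compound 3 `COc1ccc(/C=C/c2cc(OC)cc(OC)c2/C=C/C(=O)c2ccc(Cl)cc2)cc1` gives 4.9 ug/mL in a functional assay on B16-F10 cells (Mus musculus) for antiproliferative activity, read by MTT assay, with a stated time of 48 h (a lower number here means a stronger inhibitor, a higher number a weaker inhibitor), the lowest of the three numbers so far, though the margin is within the scatter. Compound 2 `COc1ccc(/C=C/c2cc(OC)cc(OC)c2/C=C/C(=O)c2ccc(C)cc2)cc1` gives 5.3 ug/mL and compound 1 `COc1ccc(/C=C/c2cc(OC)cc(OC)c2/C=C/C(=O)c2ccc(OC)cc2)cc1` gives 5.8 ug/mL in this assay. The steps among them are all small: a 1.1-fold lower number from compound 1 to compound 2 (0.04 log units; within the scatter), a 1.2-fold lower number from compound 1 to compound 3 (0.07 log units; within the scatter) and a 1.1-fold lower number from compound 2 to compound 3 (0.03 log units; within the scatter). Compound 4 `CCN(CC)c1ccc(C(=O)/C=C/c2c(/C=C/c3ccc(OC)cc3)cc(OC)cc2OC)cc1` differs from compound 3 at the same position: diethylamino in place of chloro on an aromatic carbon. Among the measured compounds shown here, all three measured steps bear on this place and none left the scatter; no measured step covers a group of this size, so the estimate is wider. No step beyond the scatter is expected, a 1.0-fold higher number from compound 3 to compound 4 (0.01 log units; within the scatter). Compound 4 is expected to give 5 ug/mL, between 2 ug/mL and 13 ug/mL.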

Compound 4, half-maximal inhibitory concentration: 8.1 ug/mL
Compound 4: middle estimate off by 1.6-fold (0.21 log units), on the low side; the measured number falls inside the stated range.
By their numbers in this assay, from the lowest: compounds 3, 2, 1 and 4 (each within the scatter of the next).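

Even with 5 heavy atoms in place of the single chlorine, the change stays within the scatter in this assay (a 1.7-fold higher number from compound 3 to compound 4 (0.22 log units; within the scatter)). The same holds against the two other substituents (a 1.5-fold higher number from compound 2 to compound 4 (0.18 log units; within the scatter)) and (a 1.4-fold higher number from compound 1 to compound 4 (0.15 log units; within the scatter)). This position thus accepts the much larger diethylamino group with no step beyond the scatter, and no measurement shown offers an explanation for these small steps.

As far as these compounds go, whether a carboxylic acid, a primary amine or a longer alkyl chain at this place would leave the scatter remains open. So does the effect of changes elsewhere on the shared core.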